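The source may report more compounds than this note shows. Statements on the series, on what has been measured and on what is new or still open speak of the compounds shown alone.

Measured in a functional assay on B16 cells (Mus musculus) for cytotoxicity, read by CCK-8 assay, with a stated time of 24 h; a lower number here means a stronger inhibitor, a higher number a weaker inhibitor:
- compound 1 `COc1ccccc1Oc1c(N)nc(-c2ccc(C)cc2)nc1Cl` gives 17400 nM
- compound 2 `COc1ccccc1Oc1c(N)nc(-c2ccccc2)nc1OCCO` gives 31100 nM
- compound 3 `COc1ccccc1Oc1c(N)nc(Cc2ccccc2)nc1OCCO` gives 47400 nM

In this assay compound 3 sits within the scatter of compound 2, and its number lies beyond the scatter above that of compound 1. The next structure is compound 4 `COc1ccccc1Oc1c(N)nc(-c2ccc(C)cc2)nc1OCCO`, which keeps the 2-hydroxyethoxy group of compound 3. The change is 4-methylphenyl in place of benzyl on an aromatic carbon and amounts to 4-methylphenyl in place of benzyl on an aromatic carbon, between two ring nitrogen atoms.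

Among the compounds with values here, one measured step bears on this position: a 1.5-fold higher number from compound 2 to compound 3 (0.18 log units; within the scatter) with benzyl in place of phenyl on an aromatic carbon. That step stays within the scatter, so swapping benzyl for an aryl group has not yet shown a clear effect here. Compound 1 also carries 4-methylphenyl, but it lacks the 2-hydroxyethoxy group and offers no matched comparison. No step beyond the scatter is therefore expected in this assay for this change. The estimated move is a 1.6-fold lower number from compound 3 to compound 4 (0.20 log units; within the scatter) and is expected to stay within the scatter. Compound 4 is estimated at 30000 nM within an expected range of 15000 nM to 60000 nM in this read-out.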

Compound 4, half-maximal inhibitory concentration: 8430 nM
Beside the measured number, compound 4's estimate is 3.6-fold (0.55 log units) above it; the measured number lies below the stated range.
By their numbers in this assay, from the lowest: compound 4; then compounds 1, 2 and 3 (each within the scatter of the next, the first and the last beyond it).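

In this assay, the aromatic carbon between two ring nitrogen atoms proves responsive after all: a 5.6-fold lower number from compound 3 to compound 4 (0.75 log units; beyond the scatter) comes with 4-methylphenyl in place of benzyl, and a 3.7-fold lower number from compound 2 to compound 4 (0.57 log units; beyond the scatter) comes with methyl in place of hydrogen, so the methyl on the aryl ring matters here, whereas a 1.5-fold higher number from compound 2 to compound 3 (0.18 log units; within the scatter) gave no clear reading of that position. With 4-methylphenyl held fixed, the other substituent position also moves the number, with a 2.1-fold lower number from compound 1 to compound 4 (0.31 log units; beyond the scatter) for 2-hydroxyethoxy in place of chloro, a modest step that places the 2-hydroxyethoxy compound lower in this pair. No supporting data are available to account for either effect.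

Going by these compounds, it remains open whether the step from methyl is specific to that group or would also appear with an ethyl, methoxy or fluoro group on the aryl ring, and whether a methyl on the benzyl ring would give a similar step. The compounds shown also leave open how far the position now holding 2-hydroxyethoxy tolerates a longer chain, an amine or a carboxylic acid.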